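This account rests on a few compounds, and the source may have more. Where it says the series, first, only, none or still open, it means among the compounds named here.

Two compounds of a shared core, compound 1 `COC(=O)c1sc2ccccc2c1C#Cc1ccc(OC)cc1` and compound 2 `COC(=O)c1sc2cc(OC)ccc2c1C#Cc1ccccc1`, have been tested in a functional assay on MCF7 cells (Homo sapiens) for cytotoxicity, read by sulforhodamine B assay, with a stated time of 48 h; a lower number here means a stronger inhibitor of growth, a higher number a weaker inhibitor of growth. In this assay compound 1 gives 90600 nM, and compound 2 gives 79600 nM; these two numbers sit within the usual scatter of each other, so compound 2 simply stands alongside compound 1. Compound 3 `COC(=O)c1sc2ccccc2c1C#Cc1ccccc1` differs from compound 2 by one change: hydrogen in place of methoxy on an aromatic carbon. Going by the values given here, no measured pair shows this change, so the step from compound 2 to compound 3 is expected to be small, a 1.1-fold higher number from compound 2 to compound 3 (0.03 log units; within the scatter), no larger than the scatter in either direction. Compound 3 is therefore estimated at 85000 nM, between 40000 nM and 170000 nM.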

Compound 3, concentration for 50% growth inhibition: 71600 nM
Compound 3: the middle estimate sits 1.2-fold (0.07 log units) above what was measured, and the stated range covers the measured number.
By their numbers in this assay, from the lowest: compounds 3, 2 and 1 (each within the scatter of the next).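

In this assay hydrogen in place of methoxy on an aromatic carbon gives a 1.1-fold lower number from compound 2 to compound 3 (0.05 log units; within the scatter) and the same change at the other methoxy group gives a 1.3-fold lower number from compound 1 to compound 3 (0.10 log units; within the scatter) and both steps lie within the scatter. At these two places, then, having a methoxy group or a hydrogen makes no difference that these numbers can resolve. No supporting measurement is available to explain this result. As far as these compounds go, whether an amine or a carboxylic acid on the same aromatic carbon would move the number beyond the scatter stays open. So does the effect of a longer chain there.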